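The source may report more compounds than this note shows. Statements on the series, on what has been measured and on what is new or still open speak of the compounds shown alone.

Working notes on the series.

Compound 1 `COc1cc2c(/C=C3/C(=O)Nc4ccc(O)cc43)c(Cl)n(Cc3cc(OC)c(OC)c(OC)c3)c2cc1C` is the benchmark here. In a functional assay on cells (Cancer cell lines, Homo sapiens) for cytotoxicity, with a stated time of 48 h (on this read-out higher numbers stand for weaker inhibition of growth and lower numbers for stronger inhibition of growth), compound 1 gives 33100 nM, the highest of the two numbers recorded so far. Among the measured compounds shown here, its nearest neighbour is compound 2 `COc1cc2c(/C=C3/C(=O)Nc4ccc(Cl)cc43)c(Cl)n(Cc3cc(OC)c(OC)c(OC)c3)c2cc1C`, which in this assay gives 7240 nM; the single measured step, a 4.6-fold lower number from compound 1 to compound 2 (0.66 log units; beyond the scatter), comes from a chloro in place of a hydroxy on an aromatic carbon and is beyond the scatter.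

Compound 3 `COc1cc2c(/C=C3/C(=O)Nc4cccc(Cl)c43)c(Cl)n(Cc3cc(OC)c(OC)c(OC)c3)c2cc1C` is not yet measured. Relative to compound 1 the change is a group of 12 heavy atoms (9 carbon, 1 nitrogen, 1 oxygen, 1 chlorine; one five-membered non-aromatic ring with 1 hetero atom, one six-membered aromatic ring of carbon only) in place of a group of 12 heavy atoms (9 carbon, 1 nitrogen, 2 oxygen; one five-membered non-aromatic ring with 1 hetero atom, one six-membered aromatic ring of carbon only), on an aromatic carbon: the hydroxy-bearing oxindole unit leaves and a chloro-bearing oxindole unit enters, the chlorine now sitting at a different point of its six-membered ring than in compound 2.

For the measured compounds named here, the one step that bears on this is the hydroxy-to-chloro swap from compound 1 to compound 2, which lowered the number modestly. Replacing the hydroxy by chloro again, though at another ring carbon, is expected to move this assay in the same direction, likely by a smaller amount, as the data give no direct reading for this placement. For compound 3 the expected step is a 2.8-fold lower number from compound 1 to compound 3 (0.44 log units; beyond the scatter). Compound 3 is therefore estimated at 12000 nM, with a range from 3500 nM to 40000 nM.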

Compound 3, concentration for total growth inhibition: 11800 nM
Beside the measured number, compound 3's estimate is 1.0-fold (0.01 log units) above it; the measured number falls inside the stated range.
By their numbers in this assay, from the lowest: compounds 2 and 3 (each within the scatter of the next); then compound 1.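

The series now holds a second chloro-bearing group, and the change from the hydroxy-bearing group again gives a 2.8-fold lower number from compound 1 to compound 3 (0.45 log units; beyond the scatter) in this assay, so the lower number is not tied to the single chlorine placement seen earlier. Moving the chlorine to another carbon of the six-membered aromatic ring gives a 1.6-fold higher number from compound 2 to compound 3 (0.21 log units; within the scatter), which leaves the two chloro placements indistinguishable on this read-out and gives no sign so far that the choice of ring carbon matters. Nothing available on these compounds bears on what lies behind these differences.

Still open, from the compounds shown here alone, is whether a fluoro, a methoxy or an amine on the same ring would read like the two chloro groups or like the hydroxy, which would separate the effect of adding chlorine from that of removing the hydroxy. The compounds shown also leave open how a hydroxy at the ring carbon that carries the chlorine in compound 3 would read, so hydroxy and chloro are compared directly at one ring carbon only.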